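The source may hold more compounds than are shown below. What is called first, only, known or untested is meant among the compounds shown, and "the series" means these compounds.

Measured compounds in this study:
Compound 1, `CCn1c(C(=O)N[C@H](C)C(=O)OC)ccc1C(CC)(CC)c1ccc(OCS(=O)(=O)c2ccccc2)c(C)c1`: in a functional assay on BXPC-3 cells (Homo sapiens) for antiproliferative activity, read by MTT assay, with a stated time of 24 h (on this read-out higher numbers stand for weaker inhibition and lower numbers for stronger inhibition), compound 1 gives only the limit > 50000 nM.
Compound 2, `CCn1c(C(=O)N[C@@H](CC(=O)OC)C(=O)OC)ccc1C(CC)(CC)c1ccc(OCS(=O)(=O)c2ccccc2)c(C)c1`: compound 2 also gives only the limit > 50000 nM.
Compound 3, `CCn1c(C(=O)N[C@@H](C)CO)ccc1C(CC)(CC)c1ccc(OCS(=O)(=O)c2ccccc2)c(C)c1`: compound 3 gives 15300 nM.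

Among the compounds with values here, compound 3 thus stands as the only compound with a measured number in this assay; the two other values are limits (the limit of > 50000 nM in this assay, at which 2 of the 3 values shown sit). The readable steps both run toward compound 3: an at least 3.2-fold lower number from compound 1 to compound 3 (0.51 log units; beyond the scatter) and an at least 3.2-fold lower number from compound 2 to compound 3 (0.51 log units; beyond the scatter), whereas a step that the two limits leave unreadable from compound 1 to compound 2 cannot be sized. The account now turns to compound 4, `CCn1c(C(=O)N[C@H](CO)CCO)ccc1C(CC)(CC)c1ccc(OCS(=O)(=O)c2ccccc2)c(C)c1`, which differs from compound 3 by hydroxymethyl in place of hydrogen on a saturated chain carbon, two bonds along the chain from an amide-type nitrogen. Within the data shown here, no measured pair shows a second hydroxymethyl being added to the chain, so the two readable steps bear only indirectly: they show that the hydroxymethyl-bearing chain of compound 3 is the one that yields a number at all. On that basis compound 4 is expected to stay close to compound 3, with a 1.0-fold lower number from compound 3 to compound 4 (0.01 log units; within the scatter) as the estimated step. Compound 4 is therefore estimated at 15000 nM, in the range 5000 nM to 50000 nM.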

Compound 4, half-maximal inhibitory concentration: 15900 nM
Beside the measured number, compound 4's estimate is 1.1-fold (0.03 log units) below it; measured number inside the range.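

In this assay, the added hydroxymethyl on a saturated chain carbon, two bonds along the chain from an amide-type nitrogen, gives a 1.0-fold higher number from compound 3 to compound 4 (0.02 log units; within the scatter), so this position accepts the extra group with no readable difference. The larger 3-hydroxy-1-(hydroxymethyl)propyl chain also keeps its distance from both ester-bearing chains, with an at least 3.1-fold lower number from compound 2 to compound 4 (0.49 log units; beyond the scatter) and an at least 3.1-fold lower number from compound 1 to compound 4 (0.49 log units; beyond the scatter). The true size of these two steps stays unknown, as the values of compound 1 and compound 2 are limits of the assay: the limit of > 50000 nM in this assay, at which 2 of the 4 values shown sit.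

The compounds shown leave open whether an amine or a carboxylic acid at this chain carbon would read differently from hydroxymethyl. They also leave open whether a longer chain bearing a terminal hydroxyl would hold the number or shift it beyond the scatter.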